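The compounds below may be only part of what the source reports. "The series", "measured", "known", "first", "only" and "open" are said of these compounds alone.

Among the measured compounds shown here, compound 3, `O=[N+]([O-])c1ccccc1CNc1cc(Br)cc2[nH]ncc12`, stands highest among the three compounds measured so far in an assay for inhibition of Indoleamine 2,3-dioxygenase 1 (Homo sapiens), with stated times of 10 min and 60 min, tested at 100 uM (on this read-out lower numbers stand for a weaker effect and higher numbers for a stronger effect at the one concentration tested), where compound 3 gives 83%. Compound 2, `NCCn1ncc2c(NCc3ccccc3[N+](=O)[O-])cc(C(F)(F)F)cc21`, gives 30% in this assay, and compound 1, `O=[N+]([O-])c1cc(OCc2ccccc2)ccc1CNc1cc(C(F)(F)F)cc2[nH]ncc12`, gives 20%; both gaps to compound 3 lie beyond the usual scatter. For the measured compounds named here, compounds 1 and 2 differ from compound 3 in more than one place, so their values show only that they fall short of compound 3; no single-point step has been measured between any pair.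

Compound 4, `O=[N+]([O-])c1ccccc1CNc1cc(C(F)(F)F)cc2[nH]ncc12`, differs from compound 3 in one place: trifluoromethyl in place of bromo on an aromatic carbon. Compounds 1 and 2 both carry a trifluoromethyl group and both give lower numbers than compound 3, yet each also differs elsewhere, so they give only a rough guide. A downward step of moderate size in this assay is expected, with wide uncertainty, namely a number 33 percentage points lower from compound 3 to compound 4 (beyond the scatter). Compound 4 is therefore estimated at 50% in this assay, within a range from 20% to 80%.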

Compound 4, a percentage reported as inhibition, at one concentration (the size of the read-out at that concentration, not a potency): 76%
For compound 4 the middle estimate is 26 percentage points below the measured one; the measured number falls inside the stated range.
By their numbers in this assay, from the lowest: compounds 1 and 2 (each within the scatter of the next); then compounds 4 and 3 (each within the scatter of the next).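

In this assay, trifluoromethyl in place of bromo on an aromatic carbon gives a number 7 percentage points lower from compound 3 to compound 4 (within the scatter) and so leaves the read-out unchanged within the usual scatter, which means this position accepts either group. The one-place steps also clear trifluoromethyl of the low numbers seen earlier: hydrogen in place of 2-aminoethyl on an aromatic nitrogen gives a number 46 percentage points higher from compound 2 to compound 4 (beyond the scatter) and hydrogen in place of benzyloxy on an aromatic carbon gives a number 56 percentage points higher from compound 1 to compound 4 (beyond the scatter) in the same assay, so those low numbers go with the 2-aminoethyl and benzyloxy groups. Nothing measured here explains any of these steps.

From the compounds shown here alone, whether this position would also accept a very different group, such as an amine or a carboxylic acid, remains open. Going by these compounds, each number comes from a single concentration, so any difference in potency between compound 3 and compound 4 also stays unknown.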